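Carboxy to (2-methoxyethyl)carbamoyl: a solubility estimate

The compounds below may be only part of what the source reports. "The series", "measured", "known", "first", "only" and "open" are said of these compounds alone.

Compound 1 `Cc1cc(C(=O)O)ccc1-c1c(N)c(C(=O)c2ccc(F)cc2F)cc[n+]1[O-]` and compound 2 `Cc1cccc(C)c1-c1c(N)c(C(=O)c2ccc(F)cc2F)cc[n+]1[O-]` share a core and have both been measured in a physicochemical assay for solubility, at pH 0.1; on this read-out lower numbers stand for lower solubility and higher numbers for higher solubility. Compound 1 gives 41 ug/mL, and compound 2 gives 40 ug/mL; the two numbers lie within the usual scatter of each other, so neither stands apart. Compound 3 `COCCNC(=O)c1ccc(-c2c(N)c(C(=O)c3ccc(F)cc3F)cc[n+]2[O-])c(C)c1` differs from compound 1 in one place: (2-methoxyethyl)amino in place of hydroxy on a carbonyl carbon. Among the compounds with values here, no measured pair shows this change, so its size is open. The expected step from compound 1 to compound 3 in this assay is a 1.2-fold higher number from compound 1 to compound 3 (0.09 log units; within the scatter), with no clear direction beyond the scatter. Compound 3 is therefore estimated at 50 ug/mL, with a range from 15 ug/mL to 160 ug/mL.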

Compound 3, solubility: 54 ug/mL
The estimate for compound 3 lay 1.1-fold (0.03 log units) below the measured number, and the stated range covers the measured number.
By their numbers in this assay, from the lowest: compounds 2, 1 and 3 (each within the scatter of the next).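

In this assay, (2-methoxyethyl)amino in place of hydroxy on a carbonyl carbon gives a 1.3-fold higher number from compound 1 to compound 3 (0.12 log units; within the scatter) and so shows that this position accepts the larger, uncharged chain with no shift beyond the scatter. Within the data shown here, this is the first measured step at this place, and it replaces an open question with a small observed size. Nothing measured here accounts for the step. From the compounds shown here alone, whether a simple amine such as dimethylamino or a longer chain ending in a hydroxy group would move the number beyond the scatter remains open.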